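Shifting a Fluorine Around the Aniline Ring of Compound 2

The source may hold more compounds than are shown below. What is called first, only, known or untested is meant among the compounds shown, and "the series" means these compounds.

Measured compounds:
compound 1 `COc1cc2ncnc(Nc3ccc(Cl)c(C(F)(F)F)c3)c2cc1OCCCCC(=O)Nc1ccc(S(N)(=O)=O)cc1` — 3910 nM
compound 2 `COc1cc2ncnc(Nc3cccc(F)c3)c2cc1OCCCCC(=O)Nc1ccc(S(N)(=O)=O)cc1` — 29900 nM

In a functional assay on A-431 cells (Homo sapiens) for antiproliferative activity, read by MTT assay, with a stated time of 72 h (a lower number here means a stronger inhibitor, a higher number a weaker inhibitor), compound 2 stands highest of the two numbers; its nearest neighbour is compound 1, and the step of a 7.6-fold higher number from compound 1 to compound 2 (0.88 log units; beyond the scatter) lies beyond the scatter. Compound 3 `COc1cc2ncnc(Nc3ccc(F)cc3)c2cc1OCCCCC(=O)Nc1ccc(S(N)(=O)=O)cc1` differs from compound 2 by 4-fluorophenyl in place of 3-fluorophenyl on a nitrogen on an aromatic ring. Going by the values given here, no measured step here compares the two fluorophenyl isomers; the single step from compound 1 to compound 2 concerns a different aniline and gives no direction. Compound 3 is therefore expected to sit near compound 2, with the step of a 1.0-fold higher number from compound 2 to compound 3 (0.00 log units; within the scatter) not beyond the scatter. Compound 3 is estimated at 30000 nM, within 10000 nM to 90000 nM.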

Compound 3, half-maximal inhibitory concentration: 18600 nM
Beside the measured number, compound 3's estimate is 1.6-fold (0.21 log units) above it, and the stated range covers the measured number.
By their numbers in this assay, from the lowest: compound 1; then compounds 3 and 2 (each within the scatter of the next).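

In this assay the fluorine's move gives a 1.6-fold lower number from compound 2 to compound 3 (0.21 log units; within the scatter) and so leaves the two fluorophenyl isomers indistinguishable at this nitrogen. Replacing 4-chloro-3-(trifluoromethyl)phenyl with 4-fluorophenyl gives a 4.8-fold higher number from compound 1 to compound 3 (0.68 log units; beyond the scatter) and shows that the gap to compound 1 does not depend on the 3-fluorophenyl group alone. No evidence available here accounts for either result.

On these data alone, it remains open whether a phenyl carrying only chlorine or only trifluoromethyl would match compound 1. As far as these compounds go, it is also open whether an unsubstituted phenyl would sit with compound 2 and compound 3.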